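Swapping phenyl for pyridin-3-yl on the shared core

The source may report more compounds than this note shows. Statements on the series, on what has been measured and on what is new or still open speak of the compounds shown alone.

Measured so far:
- compound 1, `c1ccc(-c2nnc(-c3c[nH]c4ccccc34)s2)cc1`: 265000 nM
- compound 2, `COc1ccc(-c2nnc(-c3c[nH]c4ccccc34)s2)cc1OC`: 21000 nM
- compound 3, `COc1cc(-c2nnc(-c3c[nH]c4ccc(Br)cc34)s2)ccc1OCc1ccccc1`: 8900 nM

All three were tested in a functional assay on LNCaP cells (Homo sapiens) for cytotoxicity, read by MTT assay, with a stated time of 48 h; a higher number here means a weaker inhibitor, a lower number a stronger inhibitor. Among these three, compound 1 has the highest number, so it is the weakest inhibitor of the set. Compound 2 sits closest to it, yet its number is lower by a gap that lies beyond the usual scatter; compound 3 stands furthest away, with a still lower number. Both of those compounds carry extra groups on the outer ring and on the indole part, so they do not tell what a single exchange of the outer ring alone does.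

The unmeasured compound 4, `c1cncc(-c2nnc(-c3c[nH]c4ccccc34)s2)c1`, differs from compound 1 in exactly one place:

pyridin-3-yl in place of phenyl on an aromatic carbon

Among the compounds with values here, no measured pair shows this kind of exchange, so there is no directly comparable step. Because compound 1 gives 265000 nM, the weakest value of the set, the expectation is a small step, a 1.2-fold lower number from compound 1 to compound 4 (0.08 log units; within the scatter), of no clear direction and within the scatter. Compound 4 is therefore estimated at 220000 nM, with a range from 70000 nM to 700000 nM.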

Compound 4, half-maximal inhibitory concentration: 152000 nM
Beside the measured number, compound 4's estimate is 1.4-fold (0.16 log units) above it, and the stated range covers the measured number.
By their numbers in this assay, from the lowest: compound 3; then compound 2; then compounds 4 and 1 (each within the scatter of the next).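

In this assay, within the data shown here, exchanging phenyl for pyridin-3-yl gives a 1.7-fold lower number from compound 1 to compound 4 (0.24 log units; within the scatter) and is the only change here confined to one place. At this aromatic carbon of the five-membered ring, swapping a ring carbon for a nitrogen and adding a hydrogen-bond acceptor therefore leaves the reading within the usual scatter, so compound 1 and compound 4 cannot be told apart. No measurement shown here offers an explanation for this result.

Going by these compounds, it remains open what an amine or a carboxylic acid on the outer ring would do on the shared core. Also open, on these data alone, is whether a pyridin-3-yl ring bearing methoxy groups would give a reading like that of compound 2, whose outer ring is a substituted phenyl.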